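Methoxy in place of bromo: a step expected within scatter

The compounds below may be only part of what the source reports. "The series", "measured", "known", "first", "only" and "open" are said of these compounds alone.

Compound 1 `Clc1ccc2c(NCCCNc3nccc(Nc4ccccc4)n3)ccnc2c1` and compound 2 `Clc1ccc2c(NCCCNc3nccc(Nc4ccc(Br)cc4)n3)ccnc2c1` share one core and differ at a single aromatic carbon. In an ADME assay on Vero cells (Chlorocebus sabaeus) for cytotoxicity, read by neutral red uptake, with a stated time of 72 h (a higher number here means a weaker inhibitor, a lower number a stronger inhibitor), compound 1 gives 12800 nM, and compound 2 gives 11200 nM. The step of a 1.1-fold lower number from compound 1 to compound 2 (0.06 log units; within the scatter) brings bromo in place of hydrogen, and the two numbers lie within the scatter of each other, so compound 2 cannot be set apart from compound 1 on these data.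

Compound 3 `COc1ccc(Nc2ccnc(NCCCNc3ccnc4cc(Cl)ccc34)n2)cc1` has not yet been measured. It differs from compound 2 by methoxy in place of bromo on an aromatic carbon. Within the data shown here, the only measured step bearing on this change is a 1.1-fold lower number from compound 1 to compound 2 (0.06 log units; within the scatter), which altered the same aromatic carbon and left the number within the scatter. On that ground no step beyond the scatter is expected in this assay in either direction. Compound 3 is therefore estimated at 12000 nM, within a range from 6000 nM to 24000 nM. The expected step is a 1.1-fold higher number from compound 2 to compound 3 (0.03 log units; within the scatter).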

Compound 3, half-maximal inhibitory concentration: 13300 nM
Compound 3: middle estimate off by 1.1-fold (0.04 log units), on the low side; low and high end bracket the measured number.
By their numbers in this assay, from the lowest: compounds 2, 1 and 3 (each within the scatter of the next).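

In this assay, a second group at this aromatic carbon, para to a large group, also leaves the number within the scatter: methoxy in place of bromo gives (a 1.2-fold higher number from compound 2 to compound 3 (0.07 log units; within the scatter)), and methoxy in place of hydrogen gives (a 1.0-fold higher number from compound 1 to compound 3 (0.02 log units; within the scatter)). Hydrogen, bromo and methoxy at this place therefore cannot be told apart, and the entry of methoxy, with its two heavy atoms and one hydrogen-bond acceptor, brings no step beyond the scatter. Nothing available here offers an explanation for this result.

As far as these compounds go, whether an amine, a carboxylic acid or a longer chain at this carbon would also stay within the scatter remains open. From the compounds shown here alone, the three compounds differ only at this one place, so how the number responds to changes elsewhere on the shared core is also open.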